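The compounds below may be only part of what the source reports. "The series", "measured", "known", "first", "only" and "open" are said of these compounds alone.

Measured so far in an ADME assay on BJ cells (Homo sapiens) for cytotoxicity, with a stated time of 72 h; a higher number here means that more compound is needed for the effect, a lower number that less compound is needed:
Compound 1 `Cc1cc(NC(=O)Nc2ccccc2F)c2ccccc2n1`: > 25000 nM, a limit of the assay.
Compound 2 `CSc1ccccc1NC(=O)Nc1cc(C)nc2ccccc12`: > 25000 nM, also a limit.
Compound 3 `COc1ccccc1NC(=O)Nc1cc(C)nc2ccccc12`: > 25000 nM, also a limit.

Compound 1 stands nowhere on a readable scale: its value is a limit only, and the same holds for the whole set, as the limit of > 25000 nM in this assay, at which 3 of the 3 values shown sit, records. The measured steps a step that the two limits leave unreadable from compound 1 to compound 2, a step that the two limits leave unreadable from compound 1 to compound 3 and a step that the two limits leave unreadable from compound 2 to compound 3 are each caught between two limits and carry no size. Compound 4 `Cc1cc(NC(=O)Nc2cccc(F)c2)c2ccccc2n1` is reached by the change (3-fluorophenyl in place of 2-fluorophenyl on an amide-type nitrogen). The measured steps change the group on the aromatic carbon; none moves the fluorine, so none bears directly on this step. With every measured value at the limit, the step that the limit leaves unreadable from compound 1 to compound 4 is expected to stay within the scatter and to leave compound 4 at the limit. Compound 4 is estimated at 30000 nM, between 15000 nM and 60000 nM.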

Compound 4, half-maximal effective concentration: > 25000 nM
Compound 4: only a limit was reported (the forecaster's own chance of this, stated with the estimate: 85%); the middle value does not contradict the limit.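

Compound 4 gives > 25000 nM in this assay, which is a limit of the assay. Compound 1 also has only a limit, so no step between compound 1 and compound 4 can be read: the limit of > 25000 nM in this assay, at which 4 of the 4 values shown sit.

Where the actual values of these compounds lie, and whether the fluorine's position matters in this assay, stays open.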